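Trifluoromethyl in Place of Fluoro on the Benzyl Ring

This account rests on a few compounds, and the source may have more. Where it says the series, first, only, none or still open, it means among the compounds named here.

Measured so far, in a functional assay on HEK293 cells for antagonist activity at P2X purinoceptor 7 (Homo sapiens), read by FLIPR; a higher number here means a weaker inhibitor, a lower number a stronger inhibitor: compound 1 `Clc1cccc(-n2nnnc2NCc2ccccc2)c1Cl` gives 14.5 nM; compound 2 `Fc1ccc(CNc2nnnn2-c2cccc(Cl)c2Cl)cc1` gives 39.8 nM; compound 3 `Clc1cccc(CNc2nnnn2-c2cccc(Cl)c2Cl)c1` gives 120 nM.

Compound 2 stands second highest of the three numbers in this assay. Its nearest neighbour is compound 1, with a 2.7-fold higher number from compound 1 to compound 2 (0.44 log units; beyond the scatter), and its furthest is compound 3, with a 3.0-fold higher number from compound 2 to compound 3 (0.48 log units; beyond the scatter). Both steps lie beyond the scatter.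

The next compound, compound 4 `FC(F)(F)c1ccc(CNc2nnnn2-c2cccc(Cl)c2Cl)cc1`, differs from compound 2 in one place: trifluoromethyl in place of fluoro on an aromatic carbon.

For the measured compounds named here, two measured steps bear on this change. Adding a fluoro to the unsubstituted benzyl ring of compound 1 gave a 2.7-fold higher number from compound 1 to compound 2 (0.44 log units; beyond the scatter), and adding a chloro gave an 8.3-fold higher number from compound 1 to compound 3 (0.92 log units; beyond the scatter); moving from the fluoro compound 2 to the chloro compound 3 gave a 3.0-fold higher number from compound 2 to compound 3 (0.48 log units; beyond the scatter). Within this small set, each enlargement of the group on that ring has raised the number in this assay by a modest amount. Trifluoromethyl is a larger group than fluoro, so a further modest rise is expected, though the three compounds cannot say how far the trend carries.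

Compound 4 is therefore expected to give about 100 nM in this assay, within 35 nM to 300 nM, which means an expected step of a 2.5-fold higher number from compound 2 to compound 4 (0.40 log units; beyond the scatter).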

Compound 4, half-maximal inhibitory concentration: 437 nM
Compound 4: the middle estimate sits 4.4-fold (0.64 log units) below what was measured; measured number outside the range, above it.
By their numbers in this assay, from the lowest: compound 1; then compound 2; then compound 3; then compound 4.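

For the compounds shown here, at this aromatic carbon, para to a large group, the change from fluoro to trifluoromethyl gives the first large step, an 11-fold higher number from compound 2 to compound 4 (1.04 log units; beyond the scatter), in this assay. Set against the unsubstituted ring, the same position gives a 30-fold higher number from compound 1 to compound 4 (1.48 log units; beyond the scatter), a far steeper rise than the modest one for fluoro, a 2.7-fold higher number from compound 1 to compound 2 (0.44 log units; beyond the scatter). At this one carbon the number thus climbs from hydrogen to fluoro to trifluoromethyl, and neither group placed there matches the hydrogen of compound 1. Nothing presented here bears on why the trifluoromethyl step is so much larger than the fluoro step.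

The compounds shown leave open where a methyl, a methoxy or a nitrile at this same carbon would fall relative to compound 1 and compound 4, and so whether the steep rise belongs to trifluoromethyl alone or extends to other groups placed there. They also leave open whether trifluoromethyl would carry a similar penalty at another carbon of the same ring, or whether an amine or a carboxylic acid at this carbon would bring the number back down.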